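From 3-Chlorophenyl to 4-Fluorophenyl on Compound 1

The compounds below may be only part of what the source reports. "The series", "measured", "known", "first", "only" and "open" are said of these compounds alone.

Going by the values given here, in a functional assay on KB cells (Homo sapiens) for inhibition, read by sulforhodamine B assay (on this read-out higher numbers stand for weaker inhibition of growth and lower numbers for stronger inhibition of growth), compound 1 `Cc1ccc2[nH]c(-c3ccc(-c4ccc(-c5cccc(Cl)c5)cc4)cc3)nc2c1` gives 2260 nM, the lowest of the three numbers measured so far. Compound 3 `Clc1cccc(-c2ccc(-c3ccc(-c4nc5ccccc5[nH]4)cc3)cc2)c1` gives 32300 nM and compound 2 `FC(F)(F)Oc1ccc(-c2ccc(-c3ccc(-c4nc5ccccc5[nH]4)cc3)cc2)cc1` gives 39100 nM, and compound 1 stands beyond the scatter from both. Compound 4 `Cc1ccc2[nH]c(-c3ccc(-c4ccc(-c5ccc(F)cc5)cc4)cc3)nc2c1` keeps the methyl group of compound 1 and carries 4-fluorophenyl in place of 3-chlorophenyl on an aromatic carbon.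

Among the compounds with values here, no measured step tests this exact swap. Within the data shown here, the one measured step, with hydrogen in place of methyl, is large: a 14-fold higher number from compound 1 to compound 3 (1.16 log units; beyond the scatter). It concerns the methyl group, which compound 4 retains, so it gives no reason to expect a loss of that size. The nearest hint on the end group comes from two compounds without the methyl group. Compound 3 gives 32300 nM and compound 2 gives 39100 nM, two close values despite different end groups. That is one pair only, and neither end group is 4-fluorophenyl, so the range must stay wide.

The expected change in this assay is none beyond the scatter, and the estimated step is a 1.1-fold higher number from compound 1 to compound 4 (0.04 log units; within the scatter). For compound 4 the estimated value is 2500 nM, with an expected range from 800 nM to 8000 nM.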

Compound 4, concentration for 50% growth inhibition: 24900 nM
Estimate against measurement, compound 4: 10-fold (1.00 log units) below; measured number outside the range, above it.
By their numbers in this assay, from the lowest: compound 1; then compounds 4, 3 and 2 (each within the scatter of the next).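

In this assay, going by these compounds alone, the end ring of compound 1 proves to be a sensitive place: with the methyl group kept, changing only this ring gives an 11-fold higher number from compound 1 to compound 4 (1.04 log units; beyond the scatter), a large step, as is the one for removing the methyl group, a 14-fold higher number from compound 1 to compound 3 (1.16 log units; beyond the scatter). The close numbers of compound 3 at 32300 nM and compound 2 at 39100 nM, both without the methyl group, therefore cannot be taken to mean that the end group hardly matters on compound 1. Nothing available here accounts for the size of this step.

The swap also changes two things at once, the halogen and its place on the ring, so the compounds shown cannot tell which of the two matters, and 3-fluorophenyl and 4-chlorophenyl would be the groups that pull them apart. Going by these compounds, it also remains open how the end ring behaves with a different kind of substituent, such as an amine or a carboxylic acid, and whether 4-fluorophenyl on the core without the methyl group would follow the same trend.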